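Thiophene amide: cyano replacing methyl, from a capped value

The source may report more compounds than this note shows. Statements on the series, on what has been measured and on what is new or still open speak of the compounds shown alone.

The series here shares an unsaturated primary amide attached to an aryl ring that carries a second six-membered aromatic ring. Compound 1 `C/C(=C\c1cc(-c2ccc(C)cc2)cs1)C(N)=O` places the amide on a five-membered heteroaromatic ring. In a functional assay on MCF7 cells (Homo sapiens) for cytotoxicity, read by CCK-8 assay, with a stated time of 24 h (on this read-out higher numbers stand for weaker inhibition and lower numbers for stronger inhibition), compound 1 reaches only the assay limit, > 50000 nM, so no number is known for it. Compound 1 thus stands at the limit described by the limit of > 50000 nM in this assay, at which 1 of the 2 values shown sits, rather than at a measured point. Compound 2 `C/C(=C\c1cccc(-c2ccc(C)cc2)c1)C(N)=O` instead carries the amide on a benzene ring, and in this assay compound 2 gives 6710 nM. Going by the values given here, no step between these two measured compounds is drawn, so their two values are simply reported side by side.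

Compound 3 `C/C(=C\c1cc(-c2ccc(C#N)cc2)cs1)C(N)=O` differs from compound 1 by cyano in place of methyl on an aromatic carbon. Among the compounds with values here, since compound 1 gives only a limit in this assay, no measured step tells how this exchange acts on the shared core. Its half-maximal inhibitory concentration is therefore expected to sit near the region of compound 1, and the expected step from compound 1 to compound 3 is an at least 1.2-fold lower number from compound 1 to compound 3 (0.09 log units; that floor lies within the scatter), not clearly beyond the scatter. Compound 3 is estimated at 40000 nM, with a plausible range from 8000 nM to 200000 nM, and a real chance that only a limit is again reported.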

Compound 3, half-maximal inhibitory concentration: 240 nM
Beside the measured number, compound 3's estimate is 170-fold (2.22 log units) above it; measured number outside the range, below it.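

In this assay, cyano in place of methyl on an aromatic carbon, para to a large group, brings an at least 200-fold lower number from compound 1 to compound 3 (2.31 log units; beyond the scatter), so this place on the shared core is far from indifferent to the group it carries. Going by these compounds alone, the earlier compounds both held methyl there and so could not show this; compound 3 is the first with a different group at this position, and it turns a compound capped by the assay into one with a measured value. The size of the step is only a floor, because compound 1 stands at a limit rather than at a number: the limit of > 50000 nM in this assay, at which 1 of the 3 values shown sits.

From the compounds shown here alone, whether another group at this place, such as a carboxylic acid, an amine or a chlorine atom, would act as cyano does stays open. So does whether the same exchange would carry over to the core of compound 2, since this single pair speaks only for the core of compound 1.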